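A few compounds are considered here, and "the series" means these few. Any claim that something is new, unique, unknown or untested is made for them only; others in the source may bear on it.

Compound 1, `COc1ccccc1/C=C(/SCc1ccc(F)cc1)C(=O)c1ccc(Cl)cc1`, gives 10000 nM in a functional assay on DU-145 cells (Homo sapiens) for inhibition, read by trypan blue exclusion, with a stated time of 96 h; a higher number here means a weaker inhibitor of growth, a lower number a stronger inhibitor of growth.
Compound 2, `O=C(/C(=C\c1ccccc1OCc1ccccc1)S(=O)(=O)Cc1ccc(F)cc1)c1ccc(Cl)cc1`, gives 10000 nM in this assay.
Compound 3, `COc1ccc(/C=C(\C(=O)c2ccc(Cl)cc2)S(=O)(=O)c2ccc(Br)cc2)cc1O`, gives 10000 nM in this assay.

All three measured compounds share a core built from a carbonyl, a chain double bond and a sulfur-linked side arm, and on the numbers shown they sit at the same figure. Compound 2 stands level with compound 1 and with compound 3 in this assay, with no change at the digits shown between any pair, so nothing can be said about order among them.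

Compound 4, `COc1ccc(S/C(=C/c2ccccc2OCc2ccccc2)C(=O)c2ccc(Cl)cc2)cc1`, is not yet measured. It differs from compound 2 in one place: (4-methoxyphenyl)sulfanyl in place of (4-fluorobenzyl)sulfonyl on a double-bonded chain carbon bound to a carbonyl carbon and a double-bonded chain carbon. Among the measured compounds shown here, no pair of measured compounds separated by a single change is available, so the size of this step cannot be read from the data. Given that compound 2, compound 1 and compound 3 all sit at one figure in this assay, the expectation is a step of no size beyond the scatter. Compound 4 is therefore estimated at 10000 nM, within 3000 nM to 30000 nM, which means an expected step of no change at the digits printed from compound 2 to compound 4 (within the scatter).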

Compound 4, concentration for 50% growth inhibition: 1000 nM
Estimate against measurement, compound 4: 10-fold (1.00 log units) above; measured number outside the range, below it.
By their numbers in this assay, from the lowest: compound 4; then compounds 1, 2 and 3 (each within the scatter of the next).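

In this assay, putting (4-methoxyphenyl)sulfanyl in place of (4-fluorobenzyl)sulfonyl on a double-bonded chain carbon bound to a carbonyl carbon and a double-bonded chain carbon gives a 10-fold lower number from compound 2 to compound 4 (1.00 log units; beyond the scatter). Among the compounds shown here, this is the first single-change pair in the set, and it shows that the number in this assay can respond to the side arm at this position, something the level figures of the earlier compounds could not reveal. The change is a bundle, though: the sulfur link, the carbon spacer and the ring substituent all differ at once, so the step belongs to the whole swap and not to any one part.

No measurement shown here speaks to the reason for this step. On these data alone, it remains open which part of the swap carries the step, and how a different group at this position, such as an amine or a carboxylic acid, would compare.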